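The source may hold more compounds than are shown below. What is called first, only, known or untested is meant among the compounds shown, and "the series" means these compounds.

Measured compounds:
- Compound 1 `COc1cc(-c2ncnn2-c2cccc(F)c2)cc(OC)c1OC`. In a functional assay on MCF7 cells (Homo sapiens) for antiproliferative activity, read by MTT assay, with a stated time of 72 h (a higher number here means a weaker inhibitor, a lower number a stronger inhibitor), compound 1 gives > 10000 nM, which is a limit of the assay and not a number.
- Compound 2 `COc1cc(-n2ncnc2-c2ccc(C)cc2)cc(OC)c1OC`. In this assay compound 2 gives 540 nM.
- Compound 3 `COc1cc(-c2ncnn2-c2cccc(N)c2)cc(OC)c1OC`. In this assay compound 3 gives > 10000 nM, again a limit of the assay and not a number.

Among the compounds with values here, compound 2 therefore stands alone as the only compound with a real number in this assay; the other two values are limits. Within the data shown here, the single measured step between neighbours, a step that the two limits leave unreadable from compound 1 to compound 3, cannot be sized because the limit of > 10000 nM in this assay, at which 2 of the 3 values shown sit, hides both ends of it, so it gives no guidance on how large a single change on an aromatic carbon can be here.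

Compound 4 `COc1cc(-n2ncnc2-c2ccc(OC(F)(F)F)cc2)cc(OC)c1OC` keeps the core of compound 2 and differs from it in one place: trifluoromethoxy in place of methyl on an aromatic carbon. Among the measured compounds shown here, no measured step involves this kind of exchange, and the one step that is recorded is unreadable, so there is no ground to expect a shift in either direction beyond the ordinary scatter of this assay.

On that basis compound 4 is expected to give about 800 nM, within a range from 250 nM to 3000 nM, an estimated step of a 1.5-fold higher number from compound 2 to compound 4 (0.17 log units; within the scatter) from its parent.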

Compound 4, half-maximal inhibitory concentration: > 10000 nM
Compound 4: a limit, no number (the forecaster's own chance of this, stated with the estimate: 10%); middle value at least 12-fold (1.09 log units) from the limit.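

Within the data shown here, the exchange of methyl for trifluoromethoxy, on an aromatic carbon para to a large group, gives the first step in this assay whose size can be read at all: an at least 18-fold higher number from compound 2 to compound 4 (1.26 log units; beyond the scatter). This position is therefore not indifferent to what sits on it, since one exchange takes a compound with a real number to a result for compound 4 that is a limit of the assay and not a number. The step has only a lower bound, and its true size stays hidden, as it does for most of the series: the limit of > 10000 nM in this assay, at which 3 of the 4 values shown sit.

With a single real number among the compounds shown, nothing separates the possible sources of this large step, as trifluoromethoxy brings 5 heavy atoms and 1 hydrogen-bond acceptor where methyl has 1 heavy atom and 0 hydrogen-bond acceptors. Going by these compounds, it remains open whether a chloro, a methoxy, an ethyl or an amine at this same place would keep a real number close to that of compound 2, or would also end at the limit.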